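Swapping 2-bromobenzyl for allyl on sulfur

This account rests on a few compounds, and the source may have more. Where it says the series, first, only, none or still open, it means among the compounds named here.

Values in a functional assay on MGC-803 cells (Homo sapiens) for inhibition, read by MTT assay, with a stated time of 72 h; on this read-out lower numbers stand for stronger inhibition and higher numbers for weaker inhibition
Compound 1 `Cc1cc(N2CC[C@@H](C)[C@@H](N(C)c3ncnc4[nH]ccc34)C2)n2ncnc2n1` gives 4350 nM
Compound 2 `C[C@@H]1CCN(c2cc(-c3ccccc3)nc3ncnn23)C[C@@H]1N(C)c1ncnc2[nH]ccc12` gives 84900 nM
Compound 3 `Cc1cc(N2CC[C@@H](C)[C@@H](N(C)c3ncnc4[nH]ccc34)C2)n2nc(SCc3ccccc3Br)nc2n1` gives 27000 nM

Among these three, compound 3 (27000 nM) is second highest, so it sits in the middle. Compound 4 `C=CCSc1nc2nc(C)cc(N3CC[C@@H](C)[C@@H](N(C)c4ncnc5[nH]ccc45)C3)n2n1` has vinyl in place of 2-bromophenyl on a saturated chain carbon bound to a sulfur. The closest evidence is the modest step (a 6.2-fold higher number from compound 1 to compound 3 (0.79 log units; beyond the scatter)) that came with (2-bromobenzyl)sulfanyl in place of hydrogen on an aromatic carbon. The large step (a 20-fold higher number from compound 1 to compound 2 (1.29 log units; beyond the scatter)), phenyl in place of methyl on an aromatic carbon, involves a different group and bears only loosely. Allylsulfanyl has no ring, so a modest move to a lower number is expected in this assay (a 2.5-fold lower number from compound 3 to compound 4 (0.39 log units; beyond the scatter)). Compound 4 is estimated at 11000 nM, within an expected range from 3500 nM to 35000 nM.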

Compound 4, half-maximal inhibitory concentration: 32600 nM
The estimate for compound 4 lay 3.0-fold (0.47 log units) below the measured number; the measured number falls inside the stated range.
By their numbers in this assay, from the lowest: compound 1; then compounds 3 and 4 (each within the scatter of the next); then compound 2.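

Replacing 2-bromophenyl with vinyl on the saturated chain carbon bound to sulfur leaves no difference that can be read in this assay (a 1.2-fold higher number from compound 3 to compound 4 (0.08 log units; within the scatter)). The aromatic ring and bromine are therefore not needed for the value seen with compound 3, and a sulfur-linked group without a ring still gives a higher number than hydrogen on that aromatic carbon (a 7.5-fold higher number from compound 1 to compound 4 (0.87 log units; beyond the scatter)). No supporting measurement explains either step. Open, as far as these compounds go, is whether an amine or a carboxylic acid in place of the sulfur-linked group would bring the number back towards that of compound 1.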